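The compounds below may be only part of what the source reports. "The series", "measured", "known", "first", "only" and "open" are said of these compounds alone.

Compound 1 `COc1ccc(Cn2cc(CN3C(=O)COc4ccccc43)nn2)cc1`: > 100000 nM
Compound 2 `O=C1COc2ccccc2N1Cc1cn(Cc2ccc([N+](=O)[O-])cc2)nn1`: 29600 nM

These values come from a functional assay on Hep 3B2 cells (Homo sapiens) for cytotoxicity, read by MTT assay, with a stated time of 6 days; a lower number here means a stronger inhibitor, a higher number a weaker inhibitor. Compound 1 gives > 100000 nM, which is a limit and not a number. For the measured compounds named here, compound 2, at 29600 nM, therefore holds the only actual number so far. Compound 3 `O=C1COc2ccccc2N1Cc1cn(C/C=C/c2ccccc2)nn1` differs from it by 2-phenylethenyl in place of 4-nitrophenyl on a saturated chain carbon bound to an aromatic nitrogen. Going by the values given here, the one measured step bearing on this change is an at least 3.3-fold lower number from compound 1 to compound 2 (0.52 log units; beyond the scatter), with nitro in place of methoxy on an aromatic carbon. Compound 3 has no nitro, so a modest move toward weaker inhibition is expected, though this single step is thin support. The expected step is a 1.7-fold higher number from compound 2 to compound 3 (0.23 log units; within the scatter). For compound 3 the estimated value is 50000 nM, with an expected range of 15000 nM to 150000 nM.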

Compound 3, half-maximal inhibitory concentration: 38900 nM
Compound 3: the middle estimate sits 1.3-fold (0.11 log units) above what was measured; the range from low to high includes it.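

In this assay, 2-phenylethenyl in place of 4-nitrophenyl on a saturated chain carbon bound to an aromatic nitrogen gives a 1.3-fold higher number from compound 2 to compound 3 (0.12 log units; within the scatter), so a group without nitro sits level with compound 2. Against 4-methoxyphenyl, the same group gives an at least 2.5-fold lower number from compound 1 to compound 3 (0.41 log units; beyond the scatter). Compound 1 holds a limit and not a number, and that step leans on it: the limit of > 100000 nM in this assay, at which 1 of the 3 values shown sits.

From the compounds shown here alone, what an amine or a carboxylic acid on the aromatic ring would do here remains open. So does the effect of a longer saturated chain in place of 2-phenylethenyl.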